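A few compounds are considered here, and "the series" means these few. Any claim that something is new, unique, unknown or untested is made for them only; others in the source may bear on it.

Measured compounds:
compound 1, `O=c1[nH]nc(-c2csc(-c3ccccc3)n2)o1`, 49.1%
compound 2, `S=c1[nH]nc(-c2csc(-c3ccccc3)n2)o1`, 53.8%

In a functional assay on the whole organism (strain Wistar albino) for inhibition, with Rattus norvegicus as the target, read by paw edema, with stated times of 1 h and 2 h, at a dose of 25 mg/kg by the oral route (on this read-out lower numbers stand for less inhibition and higher numbers for more inhibition at the one dose given (going by the name of the read-out)), compound 2 gives 53.8%, the highest of the two numbers; compound 1 gives 49.1%, and the two values are within the scatter, so neither can be placed above the other. Compound 3, `S=c1oc(-c2csc(-c3ccccc3)n2)nn1CN1CCCCC1`, has not been measured. It differs from compound 2 by (piperidin-1-yl)methyl in place of hydrogen on an aromatic nitrogen. Nothing measured here shows what such a change does in this assay, so compound 3 is expected to stay within the scatter of compound 2, giving an expected step of a number 2.2 percentage points higher from compound 2 to compound 3 (within the scatter). The estimate for compound 3 is 56%, with a range from 42% to 70%.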

Compound 3, a percentage reported as inhibition, in the whole organism at one dose (the size of the read-out at that dose, not a potency): 57.4%
Estimate against measurement, compound 3: 1.4 percentage points below; measured number inside the range.
By their numbers in this assay, from the lowest: compounds 1, 2 and 3 (each within the scatter of the next).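

In this assay, (piperidin-1-yl)methyl in place of hydrogen on the aromatic nitrogen gives a number 3.6 percentage points higher from compound 2 to compound 3 (within the scatter), so this position accepts the added ring and its methylene link without a change that can be told from the scatter. At this dose, the hydrogen on this nitrogen is therefore not required for the read-out. No measurement bears on why the number holds. As far as these compounds go, what stays open is whether a plain methyl, a morpholin-4-ylmethyl or an open-chain diethylaminomethyl group on this nitrogen would move the number beyond the scatter of compound 2.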